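Thioether aryl variation on a shared core: chain length step

A few compounds are considered here, and "the series" means these few. Any claim that something is new, unique, unknown or untested is made for them only; others in the source may bear on it.

Compound 1 `Cn1c(=O)c2c(nc(SCCc3ccc(F)cc3)n2C)n(C)c1=O` — 71 nM
Compound 2 `COc1cccc(CCSc2nc3c(c(=O)n(C)c(=O)n3C)n2C)c1` — 125 nM
Compound 3 `Cn1c(=O)c2c(nc(SCCCc3cccc(Cl)c3)n2C)n(C)c1=O` — 62 nM

In an assay on microsomes for inhibition of Amine oxidase [flavin-containing] B (Homo sapiens), read by fluorescence and spectrophotometry, with a stated time of 20 min (on this read-out lower numbers stand for stronger inhibition and higher numbers for weaker inhibition), compound 1 stands second highest of the three numbers; its nearest neighbour is set by a 1.1-fold lower number from compound 1 to compound 3 (0.06 log units; within the scatter) and its furthest by a 1.8-fold higher number from compound 1 to compound 2 (0.25 log units; within the scatter). The third step, a 2.0-fold lower number from compound 2 to compound 3 (0.30 log units; within the scatter), is likewise within the scatter. Compound 4 `Cn1c(=O)c2c(nc(SCc3cccc(Cl)c3)n2C)n(C)c1=O` arises from compound 1 by 3-chlorophenyl in place of 4-fluorobenzyl on a saturated chain carbon bound to a sulfur. Among the measured compounds shown here, the step from compound 1 to compound 3 already exchanged the same halogen pattern on a longer chain without a change beyond the scatter, while no measured step shortens the chain to the extent seen here. On that footing the expected step in this assay is none beyond the scatter. Compound 4 is therefore expected near 80 nM (range 30 nM to 220 nM), i.e. a 1.1-fold higher number from compound 1 to compound 4 (0.05 log units; within the scatter).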

Compound 4, half-maximal inhibitory concentration: 227 nM
For compound 4 the middle estimate is 2.8-fold (0.45 log units) below the measured one; the whole stated range lies below it.
By their numbers in this assay, from the lowest: compounds 3, 1, 2 and 4 (each within the scatter of the next, the first and the last beyond it).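

In this assay this position proves sensitive: 3-chlorophenyl in place of 4-fluorobenzyl on a saturated chain carbon bound to a sulfur gives a 3.2-fold higher number from compound 1 to compound 4 (0.50 log units; beyond the scatter), the first step from compound 1 beyond the scatter. The earlier exchanges at this position, in compound 2 and compound 3, stayed within it. No available evidence accounts for this step.

On these data alone, whether the step follows the halogen or the chain remains open, as both change together in compound 4. As far as these compounds go, how an unsubstituted phenyl or an amine would read at this position is also open.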